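The source may report more compounds than this note shows. Statements on the series, on what has been measured and on what is new or still open speak of the compounds shown alone.

Three compounds share one core and differ only in the group attached to a carbonyl carbon that sits on a ring nitrogen. Compound 1 `C[C@@H](NC(=O)OC(C)(C)C)C(=O)N1CCN(CCCOc2ccc(C(=O)C3CC3)cc2)CC1` gives 83200 nM in an assay for binding affinity to histamine H2 receptor (Homo sapiens); on this read-out higher numbers stand for weaker inhibition and lower numbers for stronger inhibition. Compound 2 `CNCC(=O)N1CCN(CCCOc2ccc(C(=O)C3CC3)cc2)CC1` gives 79400 nM, and compound 3 `CCC[C@@H](N)C(=O)N1CCN(CCCOc2ccc(C(=O)C3CC3)cc2)CC1` gives 60300 nM. Compound 3 has the smallest of the three numbers, yet a 1.4-fold lower number from compound 1 to compound 3 (0.14 log units; within the scatter) and a 1.3-fold lower number from compound 2 to compound 3 (0.12 log units; within the scatter) both fall within the scatter, so the three compounds cannot be told apart on this assay. The step to compound 4 `NCCC(=O)N1CCN(CCCOc2ccc(C(=O)C3CC3)cc2)CC1` makes one change at the same carbonyl carbon: 2-aminoethyl in place of 1-aminobutyl on a carbonyl carbon. Within the data shown here, the steps that bear on it are a 1.0-fold lower number from compound 1 to compound 2 (0.02 log units; within the scatter), a 1.4-fold lower number from compound 1 to compound 3 (0.14 log units; within the scatter) and a 1.3-fold lower number from compound 2 to compound 3 (0.12 log units; within the scatter), all of which swapped groups at this very position without moving the number beyond the scatter. For compound 4 the expectation is therefore a 1.2-fold higher number from compound 3 to compound 4 (0.06 log units; within the scatter), that is, no change beyond the scatter. The estimate for compound 4 is 70000 nM, with a range from 30000 nM to 160000 nM.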

Compound 4, inhibition constant: 100000 nM
Compound 4: middle estimate off by 1.4-fold (0.15 log units), on the low side, within the range that was stated.
By their numbers in this assay, from the lowest: compounds 3, 2, 1 and 4 (each within the scatter of the next).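

Swapping 1-aminobutyl for the smaller 2-aminoethyl, which has no defined stereocentre, gives a 1.7-fold higher number from compound 3 to compound 4 (0.22 log units; within the scatter) on this assay and so adds a new kind of change at this carbonyl carbon without moving the number beyond the scatter. Moving the nitrogen from methylamino to a chain-end amine gives a 1.3-fold higher number from compound 2 to compound 4 (0.10 log units; within the scatter) and replacing the protected amine of compound 1 gives a 1.2-fold higher number from compound 1 to compound 4 (0.08 log units; within the scatter) and these steps too leave all four compounds impossible to tell apart. No measured evidence is available to explain this flat result.

The compounds shown leave open whether a carboxylic acid, a simple methyl group without an amine or a longer chain such as 4-aminobutyl at this carbonyl carbon would move the number beyond the scatter. Going by these compounds, whether changes elsewhere in the shared core would do so also remains open.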